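This account rests on a few compounds, and the source may have more. Where it says the series, first, only, none or still open, it means among the compounds named here.

The measurements come from a physicochemical assay for acid dissociation, read by spectrophotometry. Compound 1 `O=c1ccn(CCN2CCCCC2)c(CO)c1O` gives 2.2 in this assay, and compound 2 `Cn1cc(O)c(=O)cc1CN1CCCCC1` gives 2.16. Compound 3 `CCc1c(O)c(=O)ccn1CC` gives 3.81, the highest of the three numbers; its gap to compound 1 and its gap to compound 2 both lie beyond the scatter, so compound 3 gives up its proton least readily of the measured set.

Compound 4 `CCc1c(O)c(=O)ccn1CCN(C)C` has not yet been measured. It differs from compound 3 in one place: dimethylamino in place of hydrogen on a saturated chain carbon, two bonds along the chain from an aromatic nitrogen. This brings compound 4 closer in build to compound 1, which also carries a saturated chain with a nitrogen on the aromatic nitrogen of the shared core.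

Because compound 1 gives 2.2 while compound 3 gives 3.81, a downward step is expected, estimated at a number 1.41 log units lower from compound 3 to compound 4 (beyond the scatter), well beyond the scatter. Compound 4 is therefore estimated at 2.4 in this assay, with a range from 1.9 to 3. The measurement will show whether this expectation holds.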

Compound 4, acid dissociation constant: 2.68
Compound 4: the middle estimate sits 0.28 log units below what was measured, within the range that was stated.
By their numbers in this assay, from the lowest: compounds 2 and 1 (each within the scatter of the next); then compound 4; then compound 3.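

In this assay, within the data shown here, dimethylamino in place of hydrogen on a saturated chain carbon, two bonds along the chain from an aromatic nitrogen, gives a number 1.13 log units lower from compound 3 to compound 4 (beyond the scatter) as the only change between the two structures. Among these compounds, the earlier compounds offered no pair differing in one place, so this is the first sign that the number in this assay responds to a change at this position, and the step is large. No evidence shown bears on why the number moves.

This single step does not show whether a carboxylic acid or a hydroxyl group at the same place would give a step of similar size. Nor does it show whether a longer chain carrying the dimethylamino group would keep the number where it now stands.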